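Z to E double bond in the series

This account rests on a few compounds, and the source may have more. Where it says the series, first, only, none or still open, it means among the compounds named here.

In a functional assay on the whole organism for cytotoxicity, with Homo sapiens as the target; on this read-out higher numbers stand for weaker inhibition of growth and lower numbers for stronger inhibition of growth:
- compound 1 `CCCCCCn1c(=O)oc2ccc(NCc3cc(O)ccc3O)cc2c1=O`: 2400 nM
- compound 2 `Oc1ccc(O)c(CNc2ccc(O)c(/C=C\CCc3ccccc3)c2)c1`: 11600 nM

Compound 2, at 11600 nM, holds the higher of the two numbers, and its gap to compound 1 lies beyond the scatter. Compound 3 `Oc1ccc(O)c(CNc2ccc(O)c(/C=C/CCc3ccccc3)c2)c1` is related to compound 2 by the two compounds have the same atoms and bonds and differ only in configuration as drawn: 1 of 1 stereo elements differ; a double bond is drawn Z in compound 2 and E in compound 3: a double bond is drawn Z in compound 2 and E in compound 3. Going by the values given here, no measured pair shows the effect of such a change. No step beyond the scatter is expected in this assay, and the estimated step of a 1.3-fold lower number from compound 2 to compound 3 (0.11 log units; within the scatter) is small. For compound 3 the expected value is 9000 nM, with an estimated range of 3000 nM to 25000 nM.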

Compound 3, concentration for 50% growth inhibition: 16300 nM
For compound 3 the middle estimate is 1.8-fold (0.26 log units) below the measured one, within the range that was stated.
By their numbers in this assay, from the lowest: compound 1; then compounds 2 and 3 (each within the scatter of the next).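

In this assay, moving the double bond from Z to E gives a 1.4-fold higher number from compound 2 to compound 3 (0.15 log units; within the scatter), so on this read-out the drawn geometry of this double bond does not separate the two compounds. This is the first pair in the series that isolates a single change, and it sets that change apart from the other structural differences in the series: the fact that compounds 2 and 3 differ only in the configuration as drawn

Left open is whether a saturated chain in place of the double bond, or a chain carrying an amine or a carboxylic acid, would give a step beyond the scatter. Going by these compounds alone, compound 1 differs from compound 2 and compound 3 in more than one place, so no step to it can be read.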